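This account rests on a few compounds, and the source may have more. Where it says the series, first, only, none or still open, it means among the compounds named here.

Measured so far in an ADME assay on the whole organism for inhibition, with Triticum aestivum as the target, with a stated time of 5 days; a lower number here means a stronger inhibitor, a higher number a weaker inhibitor:

- compound 1, `CCC1Oc2ccc(Cl)cc2N(O)C1=O`: 130000 nM
- compound 3, `CCC1Oc2ccc(F)cc2N(O)C1=O`: 63100 nM
- compound 2, `CCCCC(=O)ON1C(=O)COc2ccc(Cl)cc21`: 26600 nM

Compound 3 differs from compound 1 by one change, (fluoro in place of chloro on an aromatic carbon). In this assay this gave a 2.1-fold lower number from compound 1 to compound 3 (0.31 log units; beyond the scatter). Compound 2 carries a different core; how the core of compound 2 differs from the core of compound 1 is not broken down here. Of the three measured numbers, compound 2 has the lowest; compound 3 stands nearest to it and compound 1 furthest, both gaps beyond the scatter.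

Compound 4, `CCCCC(=O)ON1C(=O)COc2ccc(F)cc21`, is not yet measured in this assay. It differs from compound 2 by fluoro in place of chloro on an aromatic carbon. The place of this change is described in the same words as for the change from compound 1 to compound 3, so the two are the same change, made on two different cores. Among the compounds shown the change occurs twice, and only the instance from compound 1 to compound 3 has a measurement; there is no second measured instance to show whether the step carries over to the core of compound 2.

The expectation for compound 4 therefore rests on that single measured step. For the measured compounds named here, from compound 2 a step of a 2.0-fold lower number from compound 2 to compound 4 (0.31 log units; beyond the scatter) is expected, set beside a 2.1-fold lower number from compound 1 to compound 3 (0.31 log units; beyond the scatter), because the change is the same and a 2.1-fold lower number from compound 1 to compound 3 (0.31 log units; beyond the scatter) is the only guide available. For compound 4 the estimate in this assay is 13000 nM, with a range from 6000 nM to 30000 nM that allows for the step not transferring fully to the new core.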

Compound 4, half-maximal inhibitory concentration: 58200 nM
Beside the measured number, compound 4's estimate is 4.5-fold (0.65 log units) below it, outside the stated range (above it).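

In this assay, fluoro in place of chloro on an aromatic carbon does not carry over between these two cores as a fixed step, and its direction reverses: the same change on two cores in this assay, a 2.1-fold lower number (0.31 log units; beyond the scatter) from compound 1 to compound 3 and a 2.2-fold higher number (0.34 log units; beyond the scatter) from compound 2 to compound 4, 4.5-fold (0.65 log units) apart, beyond the scatter of two such steps

The new result, a 2.2-fold higher number from compound 2 to compound 4 (0.34 log units; beyond the scatter), means that the step measured on the core of compound 1 does not give even the direction of the change on the core of compound 2. For the compounds shown here, this rests on only two matched pairs, and the two cores differ in more than one place, so the data show that the outcome of this change depends on its core but do not assign the reversal to any one part of the core or give a cause for it.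

Still open, going by these compounds, is whether bromo or methyl on the same aromatic carbon would follow the order seen for chloro and fluoro on each core. Also open, on these data alone, is which difference between the cores decides the direction, a question that matched chloro and fluoro pairs could address by combining the pentanoyl ester with the ethyl chain, or the free hydroxy group with a core lacking that chain.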